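The source may report more compounds than this note shows. Statements on the series, on what has been measured and on what is new or still open speak of the compounds shown alone.

In a functional assay on DU-145 cells (Homo sapiens) for inhibition, read by trypan blue exclusion, with a stated time of 96 h (on this read-out higher numbers stand for weaker inhibition of growth and lower numbers for stronger inhibition of growth), compound 2 `O=C(O)c1ccc(C(=O)/C(=C\c2ccc(Cl)c([N+](=O)[O-])c2)SCc2ccccc2F)cc1` gives 1000 nM. Among the measured compounds shown here, compound 1 `O=C(O)c1ccc(C(=O)/C(=C\c2ccc(Cl)c([N+](=O)[O-])c2)SCc2ccc(Cl)cc2)cc1` gives 1000 nM, level with it, and together these are the best numbers so far. Compound 3 `COc1cc(OC)c(/C=C(/SCc2ccc(Cl)c(Cl)c2)C(=O)c2ccc(Cl)cc2)c(OC)c1`, built quite differently, gives 10000 nM, a clearly higher number and so weaker inhibition of growth.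

Compound 4 `O=C(O)c1ccc(C(=O)/C(=C\c2ccc(Cl)c([N+](=O)[O-])c2)SCc2ccc(Cl)cc2Cl)cc1` keeps the rest of compound 2 and alters one group: 2,4-dichlorophenyl in place of 2-fluorophenyl on a saturated chain carbon bound to a sulfur. In words, 2,4-dichlorophenyl stands in place of 2-fluorophenyl on a saturated chain carbon bound to a sulfur. For the measured compounds named here, only one measured step touches that same place: no change at the digits printed from compound 1 to compound 2 (within the scatter), where 2-fluorophenyl replaced 4-chlorophenyl. Going by the values given here, that single step lay within the scatter, so it offers weak but real guidance, and no measured compound yet carries the 2,4-dichlorophenyl group. No shift beyond the scatter is therefore expected, in either direction, and the estimated change is no change at the digits printed from compound 2 to compound 4 (within the scatter). For compound 4 the expected value is 1000 nM, with an estimated range of 300 nM to 3000 nM.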

Compound 4, concentration for 50% growth inhibition: 1000 nM
For compound 4 middle estimate and measured number coincide at the digits printed, within the range that was stated.
By their numbers in this assay, from the lowest: compounds 1, 2 and 4 (each within the scatter of the next); then compound 3.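

In this assay, the step to the 2,4-dichlorophenyl group reads no change at the digits printed from compound 2 to compound 4 (within the scatter), and placing chloro in place of hydrogen on an aromatic carbon reads no change at the digits printed from compound 1 to compound 4 (within the scatter). This position on the saturated chain carbon bound to a sulfur has now held three differently halogenated phenyl groups, including one with two chlorines, and all three give values within the scatter of one another. Nothing given here explains why these groups read alike. The compounds shown carry only halogens on this phenyl ring, so it remains open whether an amine or a nitrile there would leave the number level or shift it. From the compounds shown here alone, a longer chain in place of the saturated chain carbon bound to the sulfur is equally open.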